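This account rests on a few compounds, and the source may have more. Where it says the series, first, only, none or still open, it means among the compounds named here.

Compound 1 `COc1ccc(-c2cc3ccccc3c(-c3cccc(OC)c3)n2)cc1` reaches only a limit in an ADME assay on MCF-10A cells (Homo sapiens) for cytotoxicity, read by CCK-8 assay and cell counting, with a stated time of 72 h (on this read-out higher numbers stand for weaker inhibition and lower numbers for stronger inhibition), namely > 50000 nM, so no number is known for it. Compound 2 `COc1ccc(-c2cc3ccccc3c(-c3ccc(O)cc3)n2)cc1` also stands at a limit there, > 50000 nM. The step that the two limits leave unreadable from compound 1 to compound 2 therefore cannot be read, and both values sit at the limit of > 50000 nM in this assay, at which 2 of the 2 values shown sit. Compound 3 `COc1ccc(-c2cc3ccccc3c(-c3ccc(OC)cc3)n2)cc1` differs from compound 1 by 4-methoxyphenyl in place of 3-methoxyphenyl on an aromatic carbon. Among the measured compounds shown here, no measured step bears on this change, so no shift beyond the scatter is expected in this assay; the step that the limit leaves unreadable from compound 1 to compound 3 is an estimate only. Compound 3 is expected at 60000 nM, within 20000 nM to 200000 nM.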

Compound 3, half-maximal inhibitory concentration: > 50000 nM
Compound 3: only a limit was reported (the forecaster's own chance of this, stated with the estimate: 85%); the middle value does not contradict the limit.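

Among the compounds shown here, compound 1, compound 2 and compound 3 each give only a limit, not a number, so no step among them can be read: the limit of > 50000 nM in this assay, at which 3 of the 3 values shown sit. As far as these compounds go, whether 3-methoxyphenyl, 4-methoxyphenyl and 4-hydroxyphenyl differ at all in this assay stays open.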